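Nitro for hydrogen on the aryl ring of compound 3

The compounds below may be only part of what the source reports. "The series", "measured", "known", "first", "only" and "open" are said of these compounds alone.

Measured compounds:
Compound 1, `C[C@H]1CC[C@@H]2[C@@H](OC(=O)[C@]23CC(c2ccc(F)cc2)=NO3)[C@]2(C)C(=O)C=C[C@@]12O`, in a physicochemical assay for lipophilicity (a lower number here means a more polar compound, a higher number a more lipophilic compound), compound 1 gives 1.58.
Compound 2, `C[C@H]1CC[C@@H]2[C@@H](OC(=O)[C@]23CC(c2ccc(C#N)cc2)=NO3)[C@]2(C)C(=O)C=C[C@@]12O`, in this assay compound 2 gives 1.17.
Compound 3, `C[C@H]1CC[C@@H]2[C@@H](OC(=O)[C@]23CC(c2ccccc2)N(c2ccccc2)O3)[C@]2(C)C(=O)C=C[C@@]12O`, in this assay compound 3 gives 3.19.

Compound 3 stands highest of the three numbers. Its nearest neighbour is compound 1, whose number is lower beyond the scatter, and compound 2 lies furthest below it. For the measured compounds named here, the only single-place step among the measured compounds is a number 0.41 log units lower from compound 1 to compound 2 (beyond the scatter), a modest drop.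

Compound 4, `C[C@H]1CC[C@@H]2[C@@H](OC(=O)[C@]23CC(c2ccc([N+](=O)[O-])cc2)N(c2ccccc2)O3)[C@]2(C)C(=O)C=C[C@@]12O`, differs from compound 3 in one place: nitro in place of hydrogen on an aromatic carbon. Going by the values given here, no measured pair shows this exact change. Among the compounds with values here, the step from compound 1 to compound 2, in which one small polar group replaced another on the same aromatic carbon of the same kind of ring, is the only guide, and it moved this assay modestly downward. The nitro group here enters in place of a hydrogen rather than in place of fluoro, so the expected step is smaller still, and likely within the scatter, leaning slightly downward.

Compound 4 is therefore expected to give 3, within 2.6 to 3.4, which would be a step of a number 0.19 log units lower from compound 3 to compound 4 (within the scatter).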

Compound 4, partition coefficient: 3.15
For compound 4 the middle estimate is 0.15 log units below the measured one; the range from low to high includes it.
By their numbers in this assay, from the lowest: compound 2; then compound 1; then compounds 4 and 3 (each within the scatter of the next).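

In this assay, for the compounds shown here, going from phenyl to 4-nitrophenyl gives a number 0.04 log units lower from compound 3 to compound 4 (within the scatter), so at this aromatic carbon, on this core, adding nitro in place of hydrogen produces no step that can be told apart from repeat-measurement noise. Going by these compounds alone, this is the first reading for a substituent entering in place of hydrogen; the only earlier step on an aromatic ring, a number 0.41 log units lower from compound 1 to compound 2 (beyond the scatter), was a swap of one substituent for another on a different core, and it went beyond the scatter. Nothing measured here explains why the number holds where it does.

The compounds shown give one substituent at one place, so it remains open whether an amine, a carboxylic acid or a longer alkyl chain on the same aromatic carbon would also stay within the scatter of compound 3. As far as these compounds go, it also remains open whether nitro in place of hydrogen would behave the same way on the other phenyl group of compound 3, or on the core of compound 1.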